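Iodo for bromo on a growth inhibitor

This account rests on a few compounds, and the source may have more. Where it says the series, first, only, none or still open, it means among the compounds named here.

Among the compounds with values here, in a functional assay on SF-268 cells (Homo sapiens) for inhibition, read by sulforhodamine B assay, with a stated time of 48 h (on this read-out higher numbers stand for weaker inhibition of growth and lower numbers for stronger inhibition of growth), compound 1 (`Cc1ccc(NC(=O)/C=C/c2ccccc2)c(C(N)=O)c1`) stands at 10900 nM and compound 2 (`NC(=O)c1cc(Br)ccc1NC(=O)/C=C/c1ccccc1`) at 1830 nM on the same scale, the lower of the two numbers so far. Compound 3 (`NC(=O)c1cc(I)ccc1NC(=O)/C=C/c1ccccc1`) differs from compound 2 in a single group (iodo in place of bromo on an aromatic carbon): iodo in place of bromo on an aromatic carbon. Within the data shown here, only one measured step bears on this change, namely a 6.0-fold lower number from compound 1 to compound 2 (0.77 log units; beyond the scatter) when bromo took the place of methyl on an aromatic carbon. That step involves a different pair of groups and is only one observation, so it is a weak guide. A small move in the same direction, towards a lower number, is therefore expected, and no large jump. The estimated step in this assay is a 1.3-fold lower number from compound 2 to compound 3 (0.12 log units; within the scatter) and remains a cautious guess. For compound 3 the expected value is 1400 nM with a range from 500 nM to 4000 nM in this estimate.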

Compound 3, concentration for 50% growth inhibition: 2310 nM
Beside the measured number, compound 3's estimate is 1.7-fold (0.22 log units) below it; the range from low to high includes it.
By their numbers in this assay, from the lowest: compounds 2 and 3 (each within the scatter of the next); then compound 1.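

In this assay putting iodo in place of bromo gives a 1.3-fold higher number from compound 2 to compound 3 (0.10 log units; within the scatter) and so the two halogens cannot be told apart at this position. Iodo in place of methyl gives a 4.7-fold lower number from compound 1 to compound 3 (0.67 log units; beyond the scatter) and this is a clear step beyond the scatter, like the one seen earlier with bromo. The stronger growth inhibition found on leaving methyl is therefore not tied to bromo alone, since it holds for both halogens tested, though two compounds are a narrow base for any wider rule.

As far as these compounds go, whether chloro, an amine or a carboxylic acid at this same position would match the two halogens or fall back towards methyl remains open. No measurement at hand speaks to what lies behind the difference between methyl and the halogens.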